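A few compounds are considered here, and "the series" means these few. Any claim that something is new, unique, unknown or untested is made for them only; others in the source may bear on it.

Measured compounds:
- Compound 1 `O=[N+]([O-])c1ccc(CNc2cc(C(F)(F)F)cc3[nH]ncc23)cc1`: in an assay for inhibition of Tryptophan 2,3-dioxygenase (Homo sapiens), with stated times of 10 min and 60 min (a higher number here means a weaker inhibitor, a lower number a stronger inhibitor), compound 1 reaches only the limit > 100000 nM, a limit of the measurement and not a number.
- Compound 2 `FC(F)(F)c1cc(NC[C@H]2CCCCN2)c2cn[nH]c2c1`: compound 2 gives 460 nM.
- Compound 3 `Cc1ccc(CNc2cc(C(F)(F)F)cc3[nH]ncc23)c([N+](=O)O)c1`: compound 3 gives 620 nM.

Compound 2 holds the lower of the two numbers given, but the gap to compound 3 lies within the usual scatter, so the two cannot be told apart on these data. The limit for compound 1 the limit of > 100000 nM in this assay, at which 1 of the 3 values shown sits, stands apart from both.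

The step now taken goes from compound 2 to compound 4 `FC(F)(F)c1cc(NC[C@@H]2CCCCN2)c2cn[nH]c2c1`. The structural change is the two compounds have the same atoms and bonds and differ only in configuration as drawn: 1 of 1 stereo elements differ; a stereocentre at a saturated ring carbon is drawn R in compound 2 and S in compound 4. No measured pair in the set isolates a change of configuration alone, so the size and direction of the step rest on no shown comparison. Such a change can move the number either way; without any measured step to go by, the expectation is for a moderate shift, with the uncertainty spanning both directions.

The expected step from compound 2 to compound 4 is a 2.6-fold higher number from compound 2 to compound 4 (0.42 log units; beyond the scatter). Compound 4 is estimated at 1200 nM, with a range from 250 nM to 8000 nM.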

Compound 4, half-maximal inhibitory concentration: 8050 nM
The estimate for compound 4 lay 6.7-fold (0.83 log units) below the measured number; the measured number lies above the stated range.
By their numbers in this assay, from the lowest: compounds 2 and 3 (each within the scatter of the next); then compound 4. At a limit, above all of these: compound 1.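

Among these compounds, the change of configuration gives an 18-fold higher number from compound 2 to compound 4 (1.24 log units; beyond the scatter) in this assay, the first single change with a measured size. The R form as drawn holds the lower number, and the whole step can be assigned to the stereocentre at the saturated ring carbon because nothing else separates the pair: the fact that compounds 2 and 4 differ only in the configuration as drawn. Among the compounds shown here, compounds 1 and 3 carry no stereocentre, so only this pair shows that configuration at this position can move the number well beyond the scatter.

Going by these compounds, it remains open whether the same order of the two forms holds with a methyl group on the nitrogen of the saturated ring or a carboxylic acid on that ring. On these data alone, it is also open whether the step keeps its size with a nitrile in place of the trifluoromethyl on the shared core.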